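The source may hold more compounds than are shown below. What is called first, only, known or untested is meant among the compounds shown, and "the series" means these compounds.

Compound 3 `Cc1nn(C)c(Oc2ccccc2Br)c1/C=N\CCCCCCOc1cc2oc(=O)cc(C)c2cc1Cl` is the starting point here. In a functional assay on U-87MG ATCC cells for antiproliferative activity against U-87 MG (Homo sapiens), read by MTT assay, with a stated time of 72 h (a higher number here means a weaker inhibitor, a lower number a stronger inhibitor), compound 3 gives 21800 nM, the higher of the two numbers shown. Compound 2 `Cc1nn(C)c(Oc2cccc(Cl)c2)c1/C=N\CCCCCCOc1cc2oc(=O)cc(C)c2cc1Cl` gives 8460 nM in this assay, and the change a 2.6-fold higher number from compound 2 to compound 3 (0.41 log units; beyond the scatter) separates the two. Compound 1 `Cc1nn(C)c(Oc2ccc(F)c(F)c2)c1/C=N\CCCCCCOc1cc2oc(=O)cc(C)c2cc1Cl` reaches only a limit of this assay, > 25000 nM (the limit of > 25000 nM in this assay, at which 1 of the 3 values shown sits). Compound 4 `Cc1nn(C)c(Oc2ccc(OC(F)(F)F)cc2)c1/C=N\CCCCCCOc1cc2oc(=O)cc(C)c2cc1Cl` differs from compound 3 in one place: 4-(trifluoromethoxy)phenyl in place of 2-bromophenyl on an oxygen on an aromatic ring. The measured swaps of this ring, an at least 2.9-fold lower number from compound 1 to compound 2 (0.47 log units; beyond the scatter) and an at least 1.1-fold lower number from compound 1 to compound 3 (0.05 log units; that floor lies within the scatter), were modest or within the scatter, and none involves 4-(trifluoromethoxy)phenyl. Compound 4 is therefore expected to give roughly 15000 nM, between 5000 nM and 40000 nM, a step of a 1.5-fold lower number from compound 3 to compound 4 (0.16 log units; within the scatter) that may not reach beyond the scatter.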

Compound 4, half-maximal inhibitory concentration: 9620 nM
The estimate for compound 4 lay 1.6-fold (0.19 log units) above the measured number; low and high end bracket the measured number.
By their numbers in this assay, from the lowest: compounds 2 and 4 (each within the scatter of the next); then compound 3. At a limit, above all of these: compound 1.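

In this assay, the larger 4-(trifluoromethoxy)phenyl, which brings a hydrogen-bond acceptor, is tolerated in place of 2-bromophenyl, with a 2.3-fold lower number from compound 3 to compound 4 (0.36 log units; beyond the scatter). Against 3-chlorophenyl the result is a 1.1-fold higher number from compound 2 to compound 4 (0.06 log units; within the scatter), so these two different rings cannot be told apart here. Compound 1 remains a limit rather than a number, so an at least 2.5-fold lower number from compound 1 to compound 4 (0.41 log units; beyond the scatter) gives only a floor: the limit of > 25000 nM in this assay, at which 1 of the 4 values shown sits.

Going by these compounds, what an amine or a carboxylic acid on this ring would do remains open. So does the effect of moving one substituent around the ring while keeping it the same.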